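Methoxy in Place of Chloro on the Pyridine Ring

This account rests on a few compounds, and the source may have more. Where it says the series, first, only, none or still open, it means among the compounds named here.

Compound 2 `Clc1ccc(N2CC[C@@H]3CN[C@@H]3C2)cn1` is the mirror image of compound 1 `Clc1ccc(N2CC[C@H]3CN[C@H]3C2)cn1`. In a functional assay on HEK293 cells for agonist activity at Neuronal acetylcholine receptor; alpha4/beta2 (Homo sapiens), read by FLIPR (a higher number here means that more compound is needed for the effect, a lower number that less compound is needed), compound 1 gives 13 nM and compound 2 gives 24 nM; the step of a 1.8-fold higher number from compound 1 to compound 2 (0.27 log units; within the scatter) is the only one measured and goes with the fact that compounds 1 and 2 differ only in the configuration as drawn, so the two values lie within the scatter of each other. Compound 3 `COc1ccc(N2CC[C@@H]3CN[C@@H]3C2)cn1` differs from compound 2 by methoxy in place of chloro on an aromatic carbon. Going by the values given here, no measured step alters this group, so none bears directly on the change. Compound 3 is expected to give 100 nM in this assay, with a range from 30 nM to 400 nM. The expected step is a 4.2-fold higher number from compound 2 to compound 3 (0.62 log units; beyond the scatter).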

Compound 3, half-maximal effective concentration: 4980 nM
Compound 3: the middle estimate sits 50-fold (1.70 log units) below what was measured, and the stated range ends below it.
By their numbers in this assay, from the lowest: compounds 1 and 2 (each within the scatter of the next); then compound 3.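

Methoxy in place of chloro, on the aromatic carbon next to the ring nitrogen, gives a 210-fold higher number from compound 2 to compound 3 (2.32 log units; beyond the scatter) in this assay. The group at this position therefore counts for far more in these numbers than the mirror-image change between compounds 1 and 2, which stayed within the scatter. Nothing measured here explains the size of this step.

As far as these compounds go, it remains open how fluoro, an amine or a longer chain such as ethoxy would fare on this carbon. Also open, from the compounds shown here alone, is whether methoxy costs as much on the mirror-image core of compound 1.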